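The compounds below may be only part of what the source reports. "The series", "measured", "known", "first", "only" and "open" are said of these compounds alone.

Series notes. In an assay for inhibition of steroid 17-alpha-hydroxylase/17,20 lyase (Homo sapiens), using NADPH, tested at 2 uM (a higher number here means a stronger effect of the compound at the concentration tested, a lower number a weaker effect), compound 3 `CCC(c1ccc(-c2cscc2C)cc1F)n1ccnc1` gives 92% and compound 1 `CCC(c1ccc(-c2cscc2C)cc1)n1ccnc1` gives 84%. Among the measured compounds shown here, the one change between them, (hydrogen in place of fluoro on an aromatic carbon), gives a number 8 percentage points lower from compound 3 to compound 1 (within the scatter). Compound 2 `Fc1ccc(-c2csc(Cn3ccnc3)c2)cc1F` gives 25% in this assay; the difference between its core and the core of compound 3 is not broken down here. Compound 4 `Fc1ccc(-c2csc(Cn3ccnc3)c2)cc1` is not yet measured in this assay. It differs from compound 2 by hydrogen in place of fluoro on an aromatic carbon, the same kind of change as in the measured pair, though here the place is ortho to a fluoro group and meta to a large group, whereas in the measured pair it is ortho to a group of 8 heavy atoms and meta to a 4-methylthiophen-3-yl group. The expectation for compound 4 rests on a number 8 percentage points lower from compound 3 to compound 1 (within the scatter) lying within the scatter. A step of similar size is expected, a number 3 percentage points lower from compound 2 to compound 4 (within the scatter). Compound 4 is estimated to give 22%, expected between 8% and 40%.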

Compound 4, a percentage reported as inhibition, at one concentration (the size of the read-out at that concentration, not a potency): 20%
Beside the measured number, compound 4's estimate is 2 percentage points above it, within the range that was stated.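

In this assay, hydrogen in place of fluoro on an aromatic carbon gives a number 5 percentage points lower from compound 2 to compound 4 (within the scatter). Set beside the earlier step, the change shows no measurable difference between the two cores: the same change on two cores in this assay, a number 8 percentage points lower (within the scatter) from compound 3 to compound 1 and a number 5 percentage points lower (within the scatter) from compound 2 to compound 4, 3 percentage points apart, within the scatter of two such steps. Both steps lie within the scatter, so this shows no effect of the fluoro group on either core, and two cores, with the change in a different place on each, do not establish how it behaves on other cores in the series.

The compounds shown leave open whether a different group at these places, such as chloro, methoxy or a nitrile, would give a step beyond the scatter. They also leave open which structural difference separates the two cores.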